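Phenyl for pyrimidinyl on the thioether side chain

The source may report more compounds than this note shows. Statements on the series, on what has been measured and on what is new or still open speak of the compounds shown alone.

The series shares one core carrying a thioether side chain, and the numbers come from an assay on isolated protein for inhibition of aldehyde dehydrogenase 1A1 (Homo sapiens); a lower number here means a stronger inhibitor, a higher number a weaker inhibitor. Compound 1 `Cn1ncc2c(=O)n(-c3ccccc3)c(SC(C)(C)c3ccccc3)nc21` gives 1900 nM in this assay. Compound 2 `COc1ccc(C(C)Sc2nc3c(cnn3C)c(=O)n2-c2ccccc2)cc1` gives 352 nM. Compound 3 `CC(Sc1nc2c(cnn2C)c(=O)n1-c1ccccc1)c1cncnc1` gives 94 nM, the lowest of the three values, separated from the others by a 3.7-fold lower number from compound 2 to compound 3 (0.57 log units; beyond the scatter) and by a 20-fold lower number from compound 1 to compound 3 (1.31 log units; beyond the scatter), both beyond the scatter.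

Compound 4 `CC(Sc1nc2c(cnn2C)c(=O)n1-c1ccccc1)c1ccccc1` differs from compound 3 in one place: phenyl in place of pyrimidin-5-yl on a saturated chain carbon bound to a saturated chain carbon and a sulfur. Within the data shown here, the step that bears most directly on this change is the one from compound 2 to compound 3, where a 4-methoxyphenyl gave way to the pyrimidin-5-yl with a modest gain; compound 4 now removes that pyrimidin-5-yl again in favour of a plain phenyl. The large step from compound 1 to compound 3 also moved away from a phenyl-bearing chain, though it changed two things at once. Compound 4 is therefore expected to give a higher number than compound 3, by a modest step, a 3.2-fold higher number from compound 3 to compound 4 (0.50 log units; beyond the scatter). The estimate for compound 4 in this assay is 300 nM, within a range from 120 nM to 750 nM.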

Compound 4, half-maximal inhibitory concentration in the aldehyde dehydrogenase 1A1 assay: 130 nM
Beside the measured number, compound 4's estimate is 2.3-fold (0.36 log units) above it; low and high end bracket the measured number.
By their numbers in the aldehyde dehydrogenase 1A1 assay, from the lowest: compounds 3 and 4 (each within the scatter of the next); then compound 2; then compound 1.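

In the aldehyde dehydrogenase 1A1 assay, phenyl and pyrimidin-5-yl at this place cannot be told apart, a 1.4-fold higher number from compound 3 to compound 4 (0.14 log units; within the scatter), so the ring nitrogens of the pyrimidin-5-yl are not needed to reach this level. Among these compounds, compound 4 also isolates two single changes that the earlier compounds could not: hydrogen in place of the methoxy on the phenyl gives a 2.7-fold lower number from compound 2 to compound 4 (0.43 log units; beyond the scatter), and hydrogen in place of the additional methyl on the chain carbon gives a 15-fold lower number from compound 1 to compound 4 (1.16 log units; beyond the scatter). The same swap does separate the two compounds in a physicochemical assay for solubility, using the shake flask method, in phosphate buffer, with a stated time of 24 h, at pH 7.4 (on this read-out lower numbers stand for lower solubility and higher numbers for higher solubility), where compound 3 gives 264000 nM and compound 4 gives 8000 nM: the measured solubility of compound 3, 264000 nM, and of compound 4, 8000 nM, a 33-fold lower number (1.52 log units; beyond the scatter)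

The compounds shown leave open how a pyridinyl group at this place would read in the aldehyde dehydrogenase 1A1 assay and in the physicochemical assay. They also leave open what an amine on the phenyl, or a longer chain in place of the methyl on the chain carbon, would do.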